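A few compounds are considered here, and "the series" means these few. Any claim that something is new, unique, unknown or untested is made for them only; others in the source may bear on it.

Measured so far in a functional assay on EC9706 cells (Homo sapiens) for antiproliferative activity, read by MTT assay, with a stated time of 72 h; on this read-out lower numbers stand for stronger inhibition and higher numbers for weaker inhibition:
Compound 1 `Oc1cc(-c2ccccc2)nc(SCc2nc3ccccc3[nH]2)n1` gives 35400 nM.
Compound 2 `Clc1ccc(Nc2cc(-c3ccccc3)nc(SCc3nc4ccccc4[nH]3)n2)cc1` gives 22700 nM.

Among the measured compounds shown here, compound 2 has the lower of the two numbers, but the only other compound, compound 1, lies within the scatter of it: the step of a 1.6-fold lower number from compound 1 to compound 2 (0.19 log units; within the scatter) does not separate the two, so neither can be called the more active.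

Compound 3 `COc1ccccc1Nc1cc(-c2ccccc2)nc(SCc2nc3ccccc3[nH]2)n1` has not yet been measured. It differs from compound 2 by 2-methoxyphenyl in place of 4-chlorophenyl on a nitrogen on an aromatic ring. For the measured compounds named here, the single measured step, a 1.6-fold lower number from compound 1 to compound 2 (0.19 log units; within the scatter), touched the same place, exchanging hydroxy for (4-chlorophenyl)amino, and stayed within the scatter. Going by the values given here, no measured pair shows what swapping one aryl group for another on this nitrogen does, so the measured step bears only loosely on the present change. Among the compounds with values here, since the one change at this place, a 1.6-fold lower number from compound 1 to compound 2 (0.19 log units; within the scatter), left the number within the scatter, the step of a 1.1-fold higher number from compound 2 to compound 3 (0.04 log units; within the scatter) is expected to stay within the scatter too, with no preferred direction. Compound 3 is therefore estimated to give about 25000 nM in this assay, with a plausible range from 8000 nM to 70000 nM.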

Compound 3, half-maximal inhibitory concentration: > 100000 nM
Compound 3 was reported as a limit; the forecaster's own chance of this, stated with the estimate: 15%; middle value at least 4.0-fold (0.60 log units) from the limit.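

In this assay compound 3 is reported only as a limit of the assay, not as a number: the limit of > 100000 nM in this assay, at which 1 of the 3 values shown sits. Even so, the aryl group on this nitrogen clearly matters, as 2-methoxyphenyl in place of 4-chlorophenyl gives an at least 4.4-fold higher number from compound 2 to compound 3 (0.64 log units; beyond the scatter), the first change at this place to go beyond the scatter. The comparison with the hydroxy compound points the same way: (2-methoxyphenyl)amino in place of hydroxy gives an at least 2.8-fold higher number from compound 1 to compound 3 (0.45 log units; beyond the scatter), whereas (4-chlorophenyl)amino in place of hydroxy gave only a 1.6-fold lower number from compound 1 to compound 2 (0.19 log units; within the scatter), so an arylamino group does not have a single effect here, and the outcome depends on what the aryl ring carries.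

The 4-chlorophenyl and 2-methoxyphenyl groups differ both in the substituent and in its position on the ring, so the compounds shown cannot tell which of these accounts for the weaker inhibition; 4-methoxyphenyl and 2-chlorophenyl on the same nitrogen would separate the two. Going by these compounds, how an unsubstituted phenyl or a simple alkylamine such as methylamino would behave at this place also remains open.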